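Aminomethyl for Trifluoromethoxy on a Biaryl Agonist Series

The source may hold more compounds than are shown below. What is called first, only, known or untested is meant among the compounds shown, and "the series" means these compounds.

Compound 1: `N[C@@H](CC1CCCCC1)CN(C(=O)[C@@H]1C[C@H]1c1ccccc1)c1ccc(-c2ccccc2)cc1` gives 1.7 nM in a functional assay for agonist activity at G protein-coupled receptor 88 (Homo sapiens), read by HTRF and cAMP accumulation; a lower number here means that less compound is needed, a higher number that more compound is needed for the effect.
Compound 2: `CC(C)C[C@H](N)CN(C(=O)[C@@H]1C[C@H]1c1ccccc1)c1ccc(-c2ccc(C#N)cc2)cc1` gives 670 nM.
Compound 3: `CC[C@H](C)[C@H](N)CN(C(=O)[C@@H]1C[C@H]1c1ccccc1)c1ccc(-c2ccc(OC(F)(F)F)cc2)cc1` gives 170 nM.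

Of the three measured compounds, compound 3 stands second highest. Its nearest neighbour is compound 2, whose number is higher by a gap beyond the scatter, while compound 1 lies far lower, also well beyond the scatter. Compound 4, `CC[C@H](C)[C@H](N)CN(C(=O)[C@@H]1C[C@H]1c1ccccc1)c1ccc(-c2ccc(CN)cc2)cc1`, shares the whole of compound 3 except for one change on the distal ring: aminomethyl in place of trifluoromethoxy on an aromatic carbon The two measured analogues carrying a substituent on that ring, compound 2 and compound 3, both sit far above compound 1, which carries none. For the measured compounds named here, on that basis, and with no measured step for this exact exchange, a rise in this assay is expected for compound 4, most likely a moderate one beyond the scatter. The step of a 2.4-fold higher number from compound 3 to compound 4 (0.37 log units; beyond the scatter) is the estimate that follows. Compound 4 is thus expected to give 400 nM, within a range of 100 nM to 1500 nM.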

Compound 4, half-maximal effective concentration: > 30000 nM
Compound 4: no number, only a limit; the forecaster's own chance of this, stated with the estimate: 10%; at least 75-fold (1.87 log units) between middle value and limit.
By their numbers in this assay, from the lowest: compound 1; then compound 3; then compound 2. At a limit, above all of these: compound 4.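

In this assay, compound 4 gives > 30000 nM, and this is a limit of the assay rather than a number: the limit of > 30000 nM in this assay, at which 1 of the 4 values shown sits. For the compounds shown here, the exchange of trifluoromethoxy for aminomethyl on this aromatic carbon is the first change made at one place only, and it gives an at least 170-fold higher number from compound 3 to compound 4 (2.24 log units; beyond the scatter), so this position does not tolerate every substituent, and a single exchange here can carry a compound out of the measurable range. The entering group has 1 hydrogen-bond donor and the leaving group has 0, but the data do not show whether that difference is what matters.

The compounds shown leave open whether the primary amine itself accounts for the step or whether any replacement of trifluoromethoxy would do the same. A hydroxymethyl or a plain methyl group on the same carbon would separate these two readings, and an aminoethyl chain would test the distance of the amine from the ring.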